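The compounds below may be only part of what the source reports. "The series", "measured", "known", "first", "only" and "open" are said of these compounds alone.

Measured so far in a functional assay on K562 cells (Homo sapiens) for cytotoxicity, read by MTT assay, with a stated time of 5 days; a higher number here means a weaker inhibitor, a lower number a stronger inhibitor:
compound 1, `COc1ccc(-c2cnnn2Cc2cc(OC)c(OC)c(OC)c2)cc1`, 5560 nM
compound 2, `COc1ccc(-c2cnnn2Cc2cc(OC)c(OC)c(OC)c2)cc1Br`, > 10000 nM
compound 3, `COc1ccc(Cn2cc(-c3cc(OC)c(OC)c(OC)c3)nn2)cc1`, > 10000 nM

The value of compound 2 is a limit of the assay, not a number. The value of compound 3 is likewise a limit. Two of the three values therefore sit at the same point, (the limit of > 10000 nM in this assay, at which 2 of the 3 values shown sit).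

Compound 1 and compound 2 share one core and differ in a single place: bromo in place of hydrogen on an aromatic carbon. The step that this change made is an at least 1.7-fold higher number from compound 1 to compound 2 (0.25 log units; that floor lies within the scatter), toward the limit.

Compound 3 has the same atoms as compound 1, joined differently; the difference between the two cores is not broken down here.

Compound 4, `COc1ccc(Cn2cc(-c3cc(OC)c(OC)c(OC)c3)nn2)cc1Br`, has not been measured in this assay. It differs from compound 3 by bromo in place of hydrogen on an aromatic carbon, the same change, at the same place, as from compound 1 to compound 2.

Since compound 3 already gives only a limit in this assay, and the measured step of an at least 1.7-fold higher number from compound 1 to compound 2 (0.25 log units; that floor lies within the scatter) went toward a higher number, compound 4 is expected to stay at that limit, with an expected step that the limit leaves unreadable from compound 3 to compound 4. The estimate for compound 4 is 20000 nM, expected between 10000 nM and 60000 nM.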

Compound 4, half-maximal inhibitory concentration: > 10000 nM
Compound 4 was reported as a limit (the forecaster's own chance of this, stated with the estimate: 90%); the middle value lies beyond the limit too.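

In this assay compound 4 gives > 10000 nM, a limit and not a number. Compound 3 also gives only a limit, so no step can be read between compound 3 and compound 4: the limit of > 10000 nM in this assay, at which 3 of the 4 values shown sit.

The compounds shown leave open how far compound 2, compound 3 and compound 4 lie from one another, and whether the bromo change acts alike on both cores.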